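The source may hold more compounds than are shown below. What is called first, only, known or untested is meant among the compounds shown, and "the series" means these compounds.

Three analogues built on one shared core have been examined in a functional assay on HEK293 cells for agonist activity at Thyrotropin receptor (Homo sapiens), read by cAMP accumulation; on this read-out higher numbers stand for larger maximal responses and lower numbers for smaller maximal responses. Compound 1 `COc1cccc(-c2nc(SC)nc3sc(C(=O)N(C)C(C)(C)C)c(N)c23)c1` gives 3.6% in this assay, compound 2 `COc1cccc(-c2nc(SC)nc3sc(C(=O)NN)c(N)c23)c1` gives 6.1%, and compound 3 `COc1cccc(-c2nc(SC)nc3sc(C(=O)NNC(=O)OC(C)(C)C)c(N)c23)c1` gives 1.9%. Compound 3 holds the lowest of the three numbers, but its gaps to the other two are within the scatter: a number 1.7 percentage points lower from compound 1 to compound 3 (within the scatter) and a number 4.2 percentage points lower from compound 2 to compound 3 (within the scatter). Compound 4 `COc1cccc(-c2nc(SC)nc3sc(C(=O)N(C)C)c(N)c23)c1` has not yet been measured. It differs from compound 3 in one place: dimethylamino in place of ((tert-butoxycarbonyl)amino)amino on a carbonyl carbon. The step of a number 1.7 percentage points lower from compound 1 to compound 3 (within the scatter) bears on this change, compound 1 carrying methyl(tert-butyl)amino on the same carbonyl carbon, and a number 2.5 percentage points higher from compound 1 to compound 2 (within the scatter) also shows an exchange of the group on that carbonyl carbon leaving the maximal response where it was. No movement beyond the scatter is therefore expected in this assay. Compound 4 is expected to give 4%, within 0% to 12%. This corresponds to an expected step of a number 2.1 percentage points higher from compound 3 to compound 4 (within the scatter).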

Compound 4, largest response reached (reported as efficacy), in percent of the reference or control that the assay uses: 4%
Beside the measured number, compound 4's estimate shows no gap at the digits printed; the measured number falls inside the stated range.
By their numbers in this assay, from the lowest: compounds 3, 1, 4 and 2 (each within the scatter of the next).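

In this assay, dimethylamino on the carbonyl carbon leaves the maximal response unmoved against all three earlier groups: a number 2.1 percentage points higher from compound 3 to compound 4 (within the scatter), a number 2.1 percentage points lower from compound 2 to compound 4 (within the scatter) and a number 0.4 percentage points higher from compound 1 to compound 4 (within the scatter). Among these compounds, the last step is the first comparison confined to the amide-type nitrogen, with methyl in place of tert-butyl, while the first shows that going from 9 heavy atoms and 2 hydrogen-bond donors in the leaving group to 3 heavy atoms and no donors does not shift the number beyond the scatter. Nothing available here accounts for this flat picture.

These four compounds leave open whether any group on this carbonyl carbon can raise the response beyond the scatter. A carboxylic acid, or an amide of a cyclic amine such as morpholine, could answer that.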